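A few compounds are considered here, and "the series" means these few. Any claim that something is new, unique, unknown or untested is made for them only; others in the source may bear on it.

Measured in an ADME assay on J774.A1 cells (Mus musculus) for cytotoxicity, read by MTT assay, with a stated time of 48 h; on this read-out higher numbers stand for lower toxicity in this test and lower numbers for higher toxicity in this test:
Compound 1 `COc1ccc(CNC(=O)c2c([N+](=O)[O-])noc2-c2ccc([N+](=O)[O-])cc2)cc1`: 69600 nM
Compound 2 `COc1ccc(CNC(=O)c2c([N+](=O)[O-])noc2-c2ccc([N+](=O)[O-])cc2)cc1OC`: "not determined" (no result reported)
Compound 3 `CCCNC(=O)c1c([N+](=O)[O-])noc1-c1ccc([N+](=O)[O-])cc1`: 76200 nM

For the measured compounds named here, compound 1 holds one of only two numbers in this assay, and compound 3 stands within the scatter of it. Compound 4 `COc1ccc(CNC(=O)c2c([N+](=O)[O-])noc2-c2ccc(Cl)cc2Cl)cc1`, not yet measured, departs from compound 1 at one place: 2,4-dichlorophenyl in place of 4-nitrophenyl on an aromatic carbon. Going by the values given here, the only measured step, a 1.1-fold higher number from compound 1 to compound 3 (0.04 log units; within the scatter), changed the group on the amide-type nitrogen and not this aromatic group, so it gives compound 4 no direction. No change beyond the scatter is therefore expected, and the estimated step is a 1.2-fold lower number from compound 1 to compound 4 (0.06 log units; within the scatter). For compound 4 the expected value is 60000 nM, with an estimated range of 20000 nM to 150000 nM.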

Compound 4, half-maximal cytotoxic concentration: 80500 nM
Beside the measured number, compound 4's estimate is 1.3-fold (0.13 log units) below it, within the range that was stated.
By their numbers in this assay, from the lowest: compounds 1, 3 and 4 (each within the scatter of the next).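

Replacing 4-nitrophenyl with 2,4-dichlorophenyl gives a 1.2-fold higher number from compound 1 to compound 4 (0.06 log units; within the scatter) in this assay. The earlier compounds had shown a step only at the group on the amide-type nitrogen; this one shows that the number also stays within the scatter when the aromatic group next to the ring oxygen is exchanged. No available evidence bears on why this is so.

The compounds shown leave open whether an amine or a carboxylic acid on this phenyl ring would move the number beyond the scatter. They also leave open what an unsubstituted phenyl would give at this position.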